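Notes on a chloro-for-methoxy swap on the benzyl ether ring

The compounds below may be only part of what the source reports. "The series", "measured", "known", "first", "only" and "open" are said of these compounds alone.

Measured so far:
compound 1 `COc1ccc(COc2ccc(-c3nn(CCC#N)c(=O)o3)cc2)cc1`: 27 nM
compound 2 `Cc1cccc(COc2ccc(-c3nn(CCC#N)c(=O)o3)cc2)c1`: 8 nM
compound 3 `COc1cccc(COc2ccc(-c3nn(CCC#N)c(=S)o3)cc2)c1`: 100 nM

In an assay for inhibition of Amine oxidase [flavin-containing] B (Rattus norvegicus) (a lower number here means a stronger inhibitor, a higher number a weaker inhibitor), compound 3 gives the highest of the three numbers; compound 1 sits nearest and compound 2 furthest from it. Compound 4 `N#CCCn1nc(-c2ccc(OCc3cccc(Cl)c3)cc2)oc1=S` differs from compound 3 by chloro in place of methoxy on an aromatic carbon. Among the measured compounds shown here, no measured step covers a methoxy-to-chloro exchange. For the measured compounds named here, the only step, a 3.4-fold lower number from compound 1 to compound 2 (0.53 log units; beyond the scatter), concerns another change of the substituted phenyl and is modest in size; it shows that a single substituent change on that ring can shift this assay beyond the scatter. On that basis a modest step toward a lower number is expected for compound 4, a 2.0-fold lower number from compound 3 to compound 4 (0.30 log units; within the scatter). Compound 4 is estimated at 50 nM, within 15 nM to 200 nM.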

Compound 4, half-maximal inhibitory concentration: 160 nM
The estimate for compound 4 lay 3.2-fold (0.51 log units) below the measured number, within the range that was stated.
By their numbers in this assay, from the lowest: compound 2; then compound 1; then compounds 3 and 4 (each within the scatter of the next).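

In this assay, chloro in place of methoxy on this aromatic carbon gives a 1.6-fold higher number from compound 3 to compound 4 (0.20 log units; within the scatter), so 3-methoxyphenyl and 3-chlorophenyl are not told apart on the core of compound 3. A single substituent exchange on this ring therefore need not move the number beyond the scatter, unlike a 3.4-fold lower number from compound 1 to compound 2 (0.53 log units; beyond the scatter). No supporting data bear on this result.

From the compounds shown here alone, whether an amine or a carboxylic acid on this aromatic carbon would also stay within the scatter remains open. Also open, going by these compounds, is whether the chloro-for-methoxy exchange reads the same on the core of compound 2.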